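The source may report more compounds than this note shows. Statements on the series, on what has been measured and on what is new or still open speak of the compounds shown alone.

Measured compounds:
- compound 1, `CN(C)c1ccc(NCc2cncn2Cc2ccc(-c3ccccc3)cc2)cc1-c1ccccc1`, > 1000 nM
- compound 2, `COc1ccc(NCc2cncn2Cc2ccc(-c3ccccc3)cc2N)cc1-c1ccccc1`, > 1000 nM
- compound 3, `COC(=O)c1ccc(NCc2cncn2Cc2cccc(F)c2)cc1-c1ccccc1`, > 1000 nM

In a toxicity assay on NIH3T3 cells (Mus musculus) for cytotoxicity, read by resazurin assay (on this read-out higher numbers stand for an effect only at larger amounts of compound and lower numbers for an effect already at smaller amounts), compound 1 gives > 1000 nM, which is a limit of the assay and not a number. Compound 2 gives > 1000 nM in this assay, again a limit. Compound 3 gives > 1000 nM, also a limit. For the measured compounds named here, compound 1 therefore stands where every measured compound stands, because of the limit of > 1000 nM in this assay, at which 3 of the 3 values shown sit; no measured compound has a number in this assay, and no step between two measured compounds can be read.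

Compound 4, `O=C(OC1CCCCC1)c1ccc(NCc2cncn2Cc2ccc(-c3ccccc3)cc2)cc1-c1ccccc1`, has not yet been measured in this assay. It differs from compound 1 in one place: cyclohexyloxycarbonyl in place of dimethylamino on an aromatic carbon, a cyclohexyloxycarbonyl in place of dimethylamino on an aromatic carbon. Going by the values given here, since every value so far sits at the limit, the step that the limit leaves unreadable from compound 1 to compound 4 is expected to be none beyond the scatter. Compound 4 is thus expected to give about 3000 nM in this assay, within a range from 1000 nM to 10000 nM, most likely again reported only as a limit.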

Compound 4, half-maximal effective concentration: > 10000 nM
Compound 4: a limit, no number (the forecaster's own chance of this, stated with the estimate: 80%); at least 3.3-fold (0.52 log units) between middle value and limit.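

For the compounds shown here, compound 1 and compound 4 both sit at limits of this assay and not at numbers, so no step between them can be read. The compounds shown leave open what amount of any of them produces an effect in this assay, and whether cyclohexyloxycarbonyl in place of dimethylamino changes that amount.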